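Growth inhibition after swapping the aromatic group of compound 2

The compounds below may be only part of what the source reports. "The series", "measured", "known", "first", "only" and "open" are said of these compounds alone.

Compound 1 `CC1=CC[C@@H]([C@@](C)(O)CCCC(C)(C)NC(=S)N/N=C\c2ccc(C)cc2)CC1`: 80400 nM
Compound 2 `CC1=CC[C@@H]([C@@](C)(O)CCCC(C)(C)NC(=S)N/N=C\c2ccc(O)cc2)CC1`: 31500 nM

Both values come from a functional assay on HT-29 cells (Homo sapiens) for cytotoxicity, read by sulforhodamine B assay (a higher number here means a weaker inhibitor of growth, a lower number a stronger inhibitor of growth), where compound 2 has the lower of the two numbers, at 31500 nM. The next compound to consider is compound 3 `CC1=CC[C@@H]([C@@](C)(O)CCCC(C)(C)NC(=S)N/N=C(/C)c2ccccc2)CC1`. The change is a group of 9 heavy atoms (8 carbon, 1 nitrogen; one six-membered aromatic ring of carbon only) in place of a group of 9 heavy atoms (7 carbon, 1 nitrogen, 1 oxygen; one six-membered aromatic ring of carbon only), on an amide-type nitrogen. Both groups hold one six-membered aromatic ring of carbon only, but the entering group has no oxygen.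

For the measured compounds named here, only one measured step bears on this change: a 2.6-fold lower number from compound 1 to compound 2 (0.41 log units; beyond the scatter). That step puts hydroxy in place of methyl on an aromatic carbon. Compound 3, like compound 1, has no hydroxy group, so it seems reasonable to expect part or all of that modest gain to be lost. Going by the values given here, this is a thin guide, since no measured compound shows the rest of the swap on its own. In this assay, a modest move toward a higher number is therefore expected, close in size to the measured step. The expected change is a 2.1-fold higher number from compound 2 to compound 3 (0.31 log units; beyond the scatter). For compound 3, the estimated value is 65000 nM, with an expected range of 27000 nM to 150000 nM.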

Compound 3, concentration for total growth inhibition: > 100000 nM
Compound 3: no number, only a limit (the forecaster's own chance of this, stated with the estimate: 10%); middle value at least 1.5-fold (0.18 log units) away from the limit.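

In this assay compound 3 gives > 100000 nM, which is a limit of the assay and not a number: the limit of > 100000 nM in this assay, at which 1 of the 3 values shown sits.

For the compounds shown here, the swap on the amide-type nitrogen, to a group with the same count of heavy atoms but no oxygen, gives an at least 3.1-fold higher number from compound 2 to compound 3 (0.50 log units; beyond the scatter), so the earlier comparison of hydroxy with methyl is no longer the only sign that compound 2 holds an edge at this place. Set against the other compound without a hydroxy group, the result is an at least 1.2-fold higher number from compound 1 to compound 3 (0.09 log units; that floor lies within the scatter), and since that floor lies within the scatter, it does not by itself place compound 3 apart from compound 1, though among these three compounds the lowest number still belongs to the only one with a hydroxy group.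

The swap from compound 2 to compound 3 changes more than the hydroxy group alone, so the compounds shown cannot divide the loss among the parts of that change. As far as these compounds go, it also remains open whether an amine or a methoxy group on the same aromatic carbon would hold the number near that of compound 2 or let it rise toward the limit.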